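From fluoro to iodo: estimating the remaining compound

The source may report more compounds than this note shows. Statements on the series, on what has been measured and on what is new or still open speak of the compounds shown alone.

In an ADME assay on microsomes from liver (Rattus norvegicus) for metabolic stability, read by LC-MS, using NADPH, with a stated time of 30 min, tested at 1 uM (on this read-out higher numbers stand for a more stable compound and lower numbers for a less stable compound), two compounds have been measured so far. Compound 1 (`C=CC(=O)Nc1cc(Nc2ncc(I)c(Nc3ccccc3S(=O)(=O)N(C)C)n2)c(OC)cc1N(C)CCN(C)C`) gives (12%) and compound 2 (`C=CC(=O)Nc1cc(Nc2ncc(F)c(Nc3ccccc3S(=O)(=O)C(C)C)n2)c(OC)cc1N(C)CCN(C)C`) gives (11%) on this read-out. Repeat measurements of one compound always spread somewhat, and these two values lie within that usual scatter of each other. Compound 2 therefore stands level with compound 1, and little of either compound is left at the end of the test.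

The next molecule is compound 3 (`C=CC(=O)Nc1cc(Nc2ncc(I)c(Nc3ccccc3S(=O)(=O)C(C)C)n2)c(OC)cc1N(C)CCN(C)C`). It differs from compound 2 by a single change, iodo in place of fluoro on an aromatic carbon. For the measured compounds named here, no measured pair shows this swap alone, so the data give no direct size for it. Going by the values given here, the only guide is compound 1, which also carries iodo and shows (12%) in this assay as well. No shift beyond the scatter is expected, and the estimated change is small (a number 1 percentage points higher from compound 2 to compound 3 (within the scatter)) in either direction. For compound 3 the expected value is 12% with an estimated range from 5% to 22% once it is measured.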

Compound 3, percent of the compound remaining: 14%
Compound 3: the middle estimate sits 2 percentage points below what was measured; measured number inside the range.
By their numbers in this assay, from the lowest: compounds 2, 1 and 3 (each within the scatter of the next).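

In this assay, iodo in place of fluoro on an aromatic carbon now has a direct measure, with the isopropyl on the sulfonyl sulfur kept the same: a number 3 percentage points higher from compound 2 to compound 3 (within the scatter). At this position, ortho to a large group and two atoms from the ring nitrogen, fluoro and iodo therefore cannot be told apart on this read-out, even though the two groups are different atoms. The other single change, with iodo kept the same, is isopropyl in place of dimethylamino on a sulfonyl sulfur, and it gives a number 2 percentage points higher from compound 1 to compound 3 (within the scatter), so that place shows no separation either, and nothing on hand offers a reason why these numbers stay together.

The compounds shown leave open whether a different kind of group at this position, such as a nitrile or a methyl, would give a number clearly apart from these. They also leave open whether another group on the sulfonyl sulfur, such as a cyclopropyl or a morpholine, would leave more of the compound at the end of the test.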